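Sulfonylurea series: chloro on the sulfonyl phenyl of compound 2

The source may hold more compounds than are shown below. What is called first, only, known or untested is meant among the compounds shown, and "the series" means these compounds.

Three compounds carry a measurement in a functional assay on thoracic aorta (Rattus norvegicus, strain Wistar), with a stated time of 15 min; a lower number here means that less compound is needed, a higher number that more compound is needed for the effect. Compound 1 `CCOc1ccc(Br)cc1C(C)NC(=O)N(C)S(=O)(=O)c1ccc(C)cc1` gives 28600 nM and compound 3 `Cc1ccc(S(=O)(=O)N(C)C(=O)NC(C)c2cc(C)ccc2OCc2ccccc2)cc1` gives 181000 nM. For compound 2 `COc1ccc(Cl)cc1C(C)NC(=O)NS(=O)(=O)c1ccccc1` the read-out is a limit, not a number: > 300000 nM. Compound 2 therefore stands at the limit of this assay, the only one of the three to do so (the limit of > 300000 nM in this assay, at which 1 of the 3 values shown sits). Among the measured compounds shown here, no pair among compounds 1, 2 and 3 differs in a single place, so no measured step is available.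

Compound 4 `COc1ccc(Cl)cc1C(C)NC(=O)NS(=O)(=O)c1ccc(Cl)cc1` differs from compound 2 by one change: chloro in place of hydrogen on an aromatic carbon. The para position relative to the large group on the six-membered aromatic ring of carbon only takes the chloro; nothing else moves.

With compound 2 already at the limit, the expectation for compound 4 is that the change from hydrogen to chloro produces no step beyond the usual scatter, so the step from compound 2 to compound 4 is estimated as a number no higher from compound 2 to compound 4 (the limit leaves the size open). Compound 4 is expected to return 300000 nM, within 100000 nM to 1000000 nM, most probably again as a limit.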

Compound 4, half-maximal effective concentration: > 300000 nM
Compound 4: no number, only a limit (the forecaster's own chance of this, stated with the estimate: 70%); the middle value lies on the limit itself.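

Compound 2 and compound 4 both return only a limit in this assay, so no step can be read between them: the limit of > 300000 nM in this assay, at which 2 of the 4 values shown sit.

The compounds shown leave open whether chloro in place of hydrogen on the sulfonyl phenyl shifts the half-maximal effective concentration at all.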